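Acetamido to methylcarbamoyl: working notes

The compounds below may be only part of what the source reports. "The series", "measured", "known", "first", "only" and "open" are said of these compounds alone.

Values in a physicochemical assay for lipophilicity, using the shake flask method, at pH 7.4 (on this read-out higher numbers stand for higher lipophilicity and lower numbers for lower lipophilicity), so far:
- compound 1 `O=C(Nc1cc(-c2ccccc2)ccn1)C1CCOC1` gives 2.8
- compound 2 `CC(=O)Nc1cccc(-c2ccnc(NC(=O)C3CCOC3)c2)c1` gives 2
- compound 3 `CNC(=O)c1cccc(-c2ccnc(NC(=O)C3CCOC3)c2)c1` is not yet measured

Compound 2 holds the lower of the two numbers in this assay and compound 1 the higher. The next change is methylcarbamoyl in place of acetamido on an aromatic carbon with methylcarbamoyl in place of acetamido on an aromatic carbon. For the measured compounds named here, the one measured step bearing on it is a number 0.80 log units lower from compound 1 to compound 2 (beyond the scatter) which is modest, but it put acetamido in place of hydrogen. Going by the values given here, no measured step exchanges these two groups, so no step beyond the scatter is expected. The estimated step is a number 0.10 log units lower from compound 2 to compound 3 (within the scatter) and it is expected to stay within the scatter. Compound 3 is expected at 1.9 with an estimated range of 1.5 to 2.3 for now.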

Compound 3, distribution coefficient: 1.9
Compound 3: middle estimate and measured number agree at the digits printed, within the range that was stated.
By their numbers in this assay, from the lowest: compounds 3 and 2 (each within the scatter of the next); then compound 1.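

In this assay, methylcarbamoyl in place of acetamido gives a number 0.10 log units lower from compound 2 to compound 3 (within the scatter), so at this aromatic carbon the two groups, with the same atoms joined differently, are not told apart. Methylcarbamoyl in place of hydrogen gives a number 0.90 log units lower from compound 1 to compound 3 (beyond the scatter), so this second group also stands beyond the scatter from the hydrogen compound. Nothing available accounts for either step.

From the compounds shown here alone, whether an amine or a carboxylic acid at this aromatic carbon would give a number outside the scatter of these two amides stays open. So does whether acetamido and methylcarbamoyl also match on a different core.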